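Swapping the Ester Alkyl Group for a Furanylmethyl Group

The source may hold more compounds than are shown below. What is called first, only, known or untested is meant among the compounds shown, and "the series" means these compounds.

Measured compounds:
- Compound 1 `CC(C)OC(=O)C(O)Cn1cnc2c(N)ncnc21`: > 400 ug/mL
- Compound 2 `COC(=O)C(O)Cn1cnc2c(N)ncnc21`: > 400 ug/mL
- Compound 3 `CC(C)CCOC(=O)C(O)Cn1cnc2c(N)ncnc21`: 400 ug/mL

These three compounds share one core and differ only in the group placed on an oxygen next to a carbonyl group. In a functional assay on HeLa cells (Homo sapiens) for cytotoxicity (on this read-out higher numbers stand for lower toxicity in this test and lower numbers for higher toxicity in this test), compound 1 gives > 400 ug/mL, which is a limit of the assay rather than a number. Compound 2, with methyl in place of isopropyl on an oxygen next to a carbonyl group, gives > 400 ug/mL, again a limit. Compound 3, with isopentyl in that position, gives 400 ug/mL. The step that the two limits leave unreadable from compound 1 to compound 2 cannot be read. The steps of a number no higher from compound 1 to compound 3 (the limit leaves the size open) and a number no higher from compound 2 to compound 3 (the limit leaves the size open) are each no higher, with their size left open. The whole picture is framed by the limit of > 400 ug/mL in this assay, at which 2 of the 3 values shown sit.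

Compound 4 `Nc1ncnc2c1ncn2CC(O)C(=O)OCc1ccco1` differs from compound 1 in this way: (furan-2-yl)methyl in place of isopropyl on an oxygen next to a carbonyl group. Every measured step altered this same oxygen-bound group, and none of them moved the read-out in a readable way. The expected step is a number no higher from compound 1 to compound 4 (the limit leaves the size open), that is, nothing beyond the scatter. Compound 4 is therefore estimated at 400 ug/mL, in a range from 200 ug/mL to 800 ug/mL.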

Compound 4, minimum cytotoxic concentration: 40 ug/mL
For compound 4 the middle estimate is 10-fold (1.00 log units) above the measured one; the whole stated range lies above it.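

The ester position is not indifferent to its group after all. Among the simple alkyl groups, no step of readable size appeared, but (furan-2-yl)methyl on an oxygen next to a carbonyl group gives an at least 10-fold lower number from compound 1 to compound 4 (1.00 log units; beyond the scatter) in this assay, and a lower number here means higher toxicity in this test. Within the data shown here, the cleanest reading comes from the one pair with two real numbers, a 10-fold lower number from compound 3 to compound 4 (1.00 log units; beyond the scatter), which shows that the gain in toxicity does not simply follow from a larger group on this oxygen, since isopentyl is also larger than isopropyl and shows no such readable step. The other change, an at least 10-fold lower number from compound 2 to compound 4 (1.00 log units; beyond the scatter), points the same way, but its size, like that of the step from compound 1, stays open and the steps among the earlier compounds cannot be read, because they rest on a limit: the limit of > 400 ug/mL in this assay, at which 2 of the 4 values shown sit.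

With only compound 4 carrying a ring, the aromatic ring, its oxygen and the count of heavy atoms cannot be told apart here; a benzyl group, a (thiophen-2-yl)methyl group or a saturated (tetrahydrofuran-2-yl)methyl group would each separate these. From the compounds shown here alone, whether the effect needs the ester at all also stays open, and an amide or a free carboxylic acid at this place would bear on that.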